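This account rests on a few compounds, and the source may have more. Where it says the series, first, only, none or still open, it means among the compounds named here.

Compound 1 `CN1CCN(c2ccc(Nc3ncc4c(n3)N(C3CCCC3)CC(=O)N4)cc2)CC1` carries a 4-methylpiperazin-1-yl group on a benzene-type ring, and in a functional assay on HeLa cells (Homo sapiens) for inhibition, read by MTT assay, with a stated time of 48 h (on this read-out higher numbers stand for weaker inhibition and lower numbers for stronger inhibition), compound 1 gives 21300 nM. Compound 2 `O=C1CN(C2CCCC2)c2nc(Nc3ccc(N4CCCCC4)cc3)ncc2N1` differs from it in one place, (piperidin-1-yl in place of 4-methylpiperazin-1-yl on an aromatic carbon). In this assay compound 2 reaches only a limit, > 30000 nM, so its number is not known exactly. The step is therefore an at least 1.4-fold higher number from compound 1 to compound 2 (0.14 log units; that floor lies within the scatter), and it rests on (the limit of > 30000 nM in this assay, at which 1 of the 3 values shown sits).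

Compound 3 `CN1CCN(c2ccc(Nc3ncc4c(n3)N(C3CCCC3)CC(=O)N4C)nc2)CC1` has a different core; how its core differs from that of compound 1 is not broken down here. In this assay compound 3 gives 13100 nM, which sits alongside the value of compound 1 within the scatter of the method.

Compound 4 `CN1C(=O)CN(C2CCCC2)c2nc(Nc3ccc(N4CCCCC4)cn3)ncc21` is not yet measured. It differs from compound 3 in the same kind of change, (piperidin-1-yl in place of 4-methylpiperazin-1-yl on an aromatic carbon), but the surroundings differ: here the group sits on a ring with one nitrogen, two atoms from that nitrogen, rather than on a ring of carbon only. Based on compound 3 at 13100 nM and on the step of an at least 1.4-fold higher number from compound 1 to compound 2 (0.14 log units; that floor lies within the scatter), the step of a 2.3-fold higher number from compound 3 to compound 4 (0.36 log units; beyond the scatter) is expected, and compound 4 is estimated at 30000 nM, between 14000 nM and 65000 nM.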

Compound 4, half-maximal inhibitory concentration: > 30000 nM
Compound 4: only a limit was reported (the forecaster's own chance of this, stated with the estimate: 55%); the middle value lies on the limit itself.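

In this assay, putting piperidin-1-yl in place of 4-methylpiperazin-1-yl on the second core gives an at least 2.2-fold higher number from compound 3 to compound 4 (0.35 log units; beyond the scatter), so on this core the swap clearly weakens inhibition. Compound 4 gives only a limit, > 30000 nM, not an exact number. The swap raises the number on neither core by an exactly known amount, so the two cores do not disagree, but this does not show that the change carries over with the same size from one core to the other: the same change on two cores in this assay, an at least 1.4-fold higher number (0.14 log units; that floor lies within the scatter) from compound 1 to compound 2 and an at least 2.2-fold higher number (0.35 log units; beyond the scatter) from compound 3 to compound 4; the limit leaves it open whether they differ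

The compounds shown hold only these two rings at this place, so it stays open how a morpholin-4-yl ring, an unsubstituted piperazin-1-yl ring or an open-chain amine such as dimethylamino would read. Going by these compounds, it also stays open how much weaker compound 2 and compound 4 really are, since neither has an exact number to set against the others.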